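From compound 3, at the limit, to compound 4

This account rests on a few compounds, and the source may have more. Where it says the series, first, only, none or still open, it means among the compounds named here.

Values measured in a functional assay on HCT-116 cells (Homo sapiens) for inhibition, read by MTT assay, with a stated time of 48 h (a lower number here means a stronger inhibitor, a higher number a weaker inhibitor), follow
compound 1 `COc1ccc(C(=O)CSc2nnc(-c3cc(OC)c(OC)c(OC)c3)n2-c2ccc(OC)cc2)cc1` gives > 60000 nM
compound 2 `COc1ccc(CSc2nnc(-c3cc(OC)c(OC)c(OC)c3)n2-c2ccc(N(C)C)cc2)cc1` gives 1150 nM
compound 3 `COc1ccc(C(=O)CSc2nnc(-c3cc(OC)c(OC)c(OC)c3)n2-c2ccc(N(C)C)cc2)cc1` gives > 60000 nM

Compound 3 sits at the limit of > 60000 nM in this assay, at which 2 of the 3 values shown sit. In this assay compound 3 gives > 60000 nM, which is a limit and not a number. Compound 1 gives > 60000 nM, which is also a limit. Only compound 2 has a number, with 1150 nM.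

Compound 4 `COc1ccc(NC(=O)CSc2nnc(-c3cc(OC)c(OC)c(OC)c3)n2-c2ccc(N(C)C)cc2)cc1` carries (4-methoxyphenyl)amino in place of the 4-methoxyphenyl of compound 3, on a carbonyl carbon: (4-methoxyphenyl)amino in place of 4-methoxyphenyl on a carbonyl carbon. Put another way, (4-methoxyphenyl)carbonyl becomes (4-methoxyphenyl)carbamoyl.

Among the compounds with values here, no measured step makes this exact change. The change of methoxy to dimethylamino is a step that the two limits leave unreadable from compound 1 to compound 3, so it gives no size to work from. Within the data shown here, the one readable step is an at least 52-fold higher number from compound 2 to compound 3 (1.71 log units; beyond the scatter), large and beyond the scatter, and it shows that a number is reachable with this core. Compound 4 keeps the carbonyl that came with an at least 52-fold higher number from compound 2 to compound 3 (1.71 log units; beyond the scatter), so only a moderate move towards a lower number is expected, and staying at the limit remains quite possible. The expected change is an at least 5.0-fold lower number from compound 3 to compound 4 (0.69 log units; beyond the scatter). For compound 4 the estimated value is 12000 nM, with an expected range from 2000 nM to 60000 nM.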

Compound 4, half-maximal inhibitory concentration: > 60000 nM
Compound 4: only a limit was reported; the forecaster's own chance of this, stated with the estimate: 40%; middle value at least 5.0-fold (0.69 log units) from the limit.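

In this assay, the (4-methoxyphenyl)amino group on the carbonyl carbon leaves compound 4 at a limit rather than at a number, as the 4-methoxyphenyl group did in compound 3: the limit of > 60000 nM in this assay, at which 3 of the 4 values shown sit.

The steps that join two limits cannot be read, so the amide hydrogen that enters with this change has no measurable effect to report, and a change at this position has not been shown to return a number. The (4-methoxyphenyl)carbamoyl group in place of 4-methoxyphenyl on the saturated chain carbon bound to a sulfur gives an at least 52-fold higher number from compound 2 to compound 4 (1.71 log units; beyond the scatter), so among the compounds shown, compound 1, compound 3 and compound 4 all carry a carbonyl in this chain and sit at the limit, while only compound 2, without one, has a number.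

The compounds shown leave open whether the carbonyl alone accounts for this difference, and whether an amine, a carboxylic acid or a longer chain at this place would give a number. They also leave open how far compound 3 and compound 4 actually lie from each other, since neither has a number in this assay.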